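A 2-Bromophenyl Analogue Awaiting Its Cytotoxicity Value

The compounds below may be only part of what the source reports. "The series", "measured", "known", "first", "only" and "open" are said of these compounds alone.

In a functional assay on MCF7 cells (Homo sapiens) for cytotoxicity, read by MTT assay, with a stated time of 48 h (on this read-out lower numbers stand for stronger inhibition and higher numbers for weaker inhibition), the two measured compounds stand as follows:
compound 1 `Cc1cc(C)cc(-n2cc(COC(=O)c3cc4ccccc4[nH]3)nn2)c1` gives 30500 nM
compound 2 `O=C(OCc1cn(-c2cccc(C(F)(F)F)c2)nn1)c1cc2ccccc2[nH]1` gives 16500 nM

Compound 1 carries the higher of the two numbers in this assay, yet its nearest neighbour, compound 2, lies within the usual scatter of it, so the two cannot be ranked against each other. Compound 3 `O=C(OCc1cn(-c2ccccc2Br)nn1)c1cc2ccccc2[nH]1` has not yet been measured. It differs from compound 1 in one place: 2-bromophenyl in place of 3,5-dimethylphenyl on an aromatic nitrogen. For the measured compounds named here, no measured pair shows what exchanging the group on that aromatic nitrogen does, and the two known values give only the general level at which compounds of this shared core sit. On that basis compound 3 is expected to land near the same level, with a step from compound 1 to compound 3 of a 1.5-fold lower number from compound 1 to compound 3 (0.18 log units; within the scatter), which is not expected to exceed the scatter. The estimate for compound 3 in this assay is 20000 nM, within a range from 6000 nM to 65000 nM.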

Compound 3, half-maximal inhibitory concentration: 38800 nM
Compound 3: the middle estimate sits 1.9-fold (0.29 log units) below what was measured; the range from low to high includes it.
By their numbers in this assay, from the lowest: compounds 2, 1 and 3 (each within the scatter of the next, the first and the last beyond it).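

In this assay the exchange on the aromatic nitrogen of the shared core gives a 1.3-fold higher number from compound 1 to compound 3 (0.10 log units; within the scatter) and thus stays within the scatter. The earlier compounds shown here offered no pair that isolated a change at this place, whereas this pair does: 2-bromophenyl in place of 3,5-dimethylphenyl leaves compound 3 indistinguishable from compound 1. This single exchange between two carbon-only aromatic rings with different substituents therefore gives no sign that the choice between these two groups matters in this read-out. Nothing measured here offers an explanation for this result.

Going by these compounds, whether an amine or a carboxylic acid on the phenyl ring would move the number beyond the scatter remains open. So does the outcome of replacing the phenyl ring on that nitrogen with a longer alkyl chain.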